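Three aryl swaps on one shared core: compound 4

The source may hold more compounds than are shown below. What is called first, only, known or untested is meant among the compounds shown, and "the series" means these compounds.

Compound 3, `CCCn1c(=O)[nH]c2nc(-c3ccc(S(=O)(=O)N4CCN(c5ccc(I)cc5)CC4)cc3)[nH]c2c1=O`, is the reference point here. In an assay on CHO cells for displacement of a labelled ligand from adenosine receptor A3 (Homo sapiens), read by scintillation counting, with a stated time of 45 min, tested at 1 uM, in the presence of a further agent that is not named here (on this read-out higher numbers stand for more inhibition at the one concentration tested (going by the name of the read-out) and lower numbers for less inhibition), compound 3 gives 36%, the highest of the three numbers shown, although its gaps to the other two fall within the usual scatter. Compound 1, `CCCn1c(=O)[nH]c2nc(-c3ccc(S(=O)(=O)N4CCN(c5ccccc5Cl)CC4)cc3)[nH]c2c1=O`, gives 32% in this assay, and compound 2, `CCCn1c(=O)[nH]c2nc(-c3ccc(S(=O)(=O)N4CCN(c5ccccc5)CC4)cc3)[nH]c2c1=O`, gives 27%.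

Compound 4, `CCCn1c(=O)[nH]c2nc(-c3ccc(S(=O)(=O)N4CCN(c5ccc(Cl)cc5F)CC4)cc3)[nH]c2c1=O`, differs from compound 3 in one place: 4-chloro-2-fluorophenyl in place of 4-iodophenyl on an amine nitrogen in a ring. For the measured compounds named here, three measured steps bear on this change, since each of them also swaps the group on that same ring nitrogen or a halogen on its aromatic ring. The step of a number 9 percentage points higher from compound 2 to compound 3 (within the scatter) adds iodine to a bare phenyl; the step of a number 4 percentage points higher from compound 1 to compound 3 (within the scatter) trades one halogenated phenyl for another; and the step of a number 5 percentage points lower from compound 1 to compound 2 (within the scatter) removes chlorine. None of the three moves beyond the scatter, so the numbers give no sign that the identity or placement of halogens on this phenyl ring changes the read-out in this assay.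

On that basis compound 4 is expected to sit near compound 3, with an estimated step of a number 3 percentage points lower from compound 3 to compound 4 (within the scatter). The expected value for compound 4 in this assay is 33%, within a range from 18% to 48%.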

Compound 4, a percentage reported as inhibition, at one concentration (the size of the read-out at that concentration, not a potency): 14%
For compound 4 the middle estimate is 19 percentage points above the measured one; the measured number lies below the stated range.
By their numbers in this assay, from the lowest: compound 4; then compounds 2, 1 and 3 (each within the scatter of the next).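

In this assay the group on the ring nitrogen turns out to matter: the 4-chloro-2-fluorophenyl group is set apart from each of the other three groups (a number 22 percentage points lower from compound 3 to compound 4 (beyond the scatter); a number 13 percentage points lower from compound 2 to compound 4 (beyond the scatter); a number 18 percentage points lower from compound 1 to compound 4 (beyond the scatter)). For the compounds shown here, these are the first steps at this position that pass beyond the scatter, and they make compound 4 the lowest of the four compounds. Halogens on this phenyl ring therefore cannot be treated as interchangeable, although no measurement shown here accounts for the drop.

The new group differs from phenyl by both a fluorine and a chlorine, so a 2-fluorophenyl group and a 4-chlorophenyl group on the same ring nitrogen would help show whether one halogen, or the pair together, goes with the lower number. On these data alone, it also remains open how groups without halogens, such as 4-methoxyphenyl or benzyl, would read at this position in this assay and whether any of them would rise above the numbers seen so far.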